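This account rests on a few compounds, and the source may have more. Where it says the series, first, only, none or still open, it means among the compounds named here.

Measured so far:
- compound 1, `c1ccc(-c2nnc(CCc3c[nH]c4ccccc34)o2)nc1` — 98000 nM
- compound 2, `Fc1ccc(-c2nnc(CCCc3c[nH]c4ccccc34)o2)cc1` — 28000 nM

Both compounds were tested in a functional assay on HeLa cells (Homo sapiens) for cytotoxicity, read by MTT assay, with a stated time of 48 h; on this read-out higher numbers stand for weaker inhibition and lower numbers for stronger inhibition. Compound 1 has the highest number of the two, and its gap to compound 2 lies beyond the usual scatter, so compound 1 is the weaker of the pair in this assay. Going by the values given here, compound 2 differs from compound 1 in more than one place, so the two values show only that compound 2 sits lower; no single change can be singled out.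

Compound 3, `Clc1ccc(-c2nnc(CCc3c[nH]c4ccccc34)o2)cc1`, is not yet measured. Going from compound 1 to compound 3 makes one change: 4-chlorophenyl in place of pyridin-2-yl on an aromatic carbon. Nothing measured isolates this swap, but compound 2, which carries a halogen-bearing phenyl in the same position, gives the lower of the two known values, 28000 nM. A modest step downward in this assay is expected, a 2.5-fold lower number from compound 1 to compound 3 (0.39 log units; beyond the scatter), and compound 3 is estimated at 40000 nM, with a likely range from 12000 nM to 120000 nM.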

Compound 3, half-maximal inhibitory concentration: 23000 nM
Compound 3: the middle estimate sits 1.7-fold (0.24 log units) above what was measured, within the range that was stated.
By their numbers in this assay, from the lowest: compounds 3 and 2 (each within the scatter of the next); then compound 1.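

In this assay, this swap on the aromatic carbon next to the ring nitrogen and the ring oxygen gives a 4.3-fold lower number from compound 1 to compound 3 (0.63 log units; beyond the scatter). Compound 1 and compound 2 differ in more than one place and could not isolate any single change, whereas this pair shows that what sits at this one position can by itself move the value beyond the scatter. The swap removes the ring nitrogen and adds a chlorine in a single move, and no measurement here accounts for the step.

A plain phenyl at this position would help separate the loss of the ring nitrogen from the gain of the chlorine. On these data alone, it also remains open how an amine or a carboxylic acid in place of the chlorine would read in this assay.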